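Adding chloro to the phenyl of compound 3

This account rests on a few compounds, and the source may have more. Where it says the series, first, only, none or still open, it means among the compounds named here.

In a functional assay on HCT-116 cells (Homo sapiens) for antiproliferative activity, read by MTT assay, with a stated time of 72 h (on this read-out higher numbers stand for weaker inhibition and lower numbers for stronger inhibition), the series reads as follows.
- compound 1 `COc1ncc(-c2ccc3c(c2)N(c2ccc(C)cc2)C(=O)CO3)cc1NS(=O)(=O)c1ccc(F)cc1` gives 22700 nM
- compound 2 `COc1ncc(-c2ccc3c(c2)NC(=O)CO3)cc1NS(=O)(=O)c1ccc(F)cc1` gives 24900 nM
- compound 3 `COc1ncc(-c2ccc3c(c2)N(c2ccccc2)C(=O)CO3)cc1NS(=O)(=O)c1ccc(F)cc1` gives 18800 nM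

Compound 3 (18800 nM) holds no distinct place, and all steps among the three stay within the scatter. Compound 4 `COc1ncc(-c2ccc3c(c2)N(c2ccc(Cl)cc2)C(=O)CO3)cc1NS(=O)(=O)c1ccc(F)cc1` has chloro in place of hydrogen on an aromatic carbon, para to a large group (chloro in place of hydrogen on an aromatic carbon). The closest evidence is the loss of methyl at compound 1 (a 1.2-fold lower number from compound 1 to compound 3 (0.08 log units; within the scatter)). The step that puts phenyl in place of hydrogen on an amide-type nitrogen in a ring (a 1.3-fold lower number from compound 2 to compound 3 (0.12 log units; within the scatter)) and the step that puts hydrogen in place of 4-methylphenyl on that nitrogen (a 1.1-fold higher number from compound 1 to compound 2 (0.04 log units; within the scatter)) also bear on it. Within the data shown here, no chloro example has been measured. No step beyond the scatter is expected (a 1.0-fold higher number from compound 3 to compound 4 (0.00 log units; within the scatter)). The estimated value for compound 4 is 19000 nM (expected range 10000 nM to 32000 nM).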

Compound 4, half-maximal inhibitory concentration: 19200 nM
Beside the measured number, compound 4's estimate is 1.0-fold (0.00 log units) below it; the range from low to high includes it.
By their numbers in this assay, from the lowest: compounds 3, 4, 1 and 2 (each within the scatter of the next).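

In this assay chloro on this aromatic carbon, para to a large group, gives no readable change from hydrogen (a 1.0-fold higher number from compound 3 to compound 4 (0.01 log units; within the scatter)) or from methyl (a 1.2-fold lower number from compound 1 to compound 4 (0.07 log units; within the scatter)). Thus phenyl, 4-methylphenyl and 4-chlorophenyl on the amide-type nitrogen cannot be told apart here. The 4-chlorophenyl group also stays within the scatter of hydrogen on that nitrogen (a 1.3-fold lower number from compound 2 to compound 4 (0.11 log units; within the scatter)), and nothing available explains this flat reading.

Going by these compounds, whether an amine or a carboxylic acid at this position would move the number beyond the scatter remains open.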